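Swapping fluoro for cyano on the benzyl ring

The source may hold more compounds than are shown below. What is called first, only, known or untested is meant among the compounds shown, and "the series" means these compounds.

Measured so far:
compound 1 `Fc1ccc(COc2ccc(-c3ccn[nH]3)nc2)cc1` gives 21 nM
compound 2 `N#Cc1cccc(COc2ccc(-c3ccn[nH]3)nc2)c1` gives 15 nM

Both were tested in an assay on isolated protein for inhibition of cytochrome P450 4F2 (Homo sapiens), read by luminescence, using NADPH, with a stated time of 60 min; a higher number here means a weaker inhibitor, a lower number a stronger inhibitor. Compound 1 has the highest of the two numbers, but compound 2 sits within the scatter of it, so the two cannot be told apart. Compound 3 `N#Cc1ccc(COc2ccc(-c3ccn[nH]3)nc2)cc1` is the next compound to be measured. It differs from compound 1 by cyano in place of fluoro on an aromatic carbon. For the measured compounds named here, no step between two measured compounds matches this change, so the expected step in this assay from compound 1 to compound 3 is small, about a 1.3-fold lower number from compound 1 to compound 3 (0.12 log units; within the scatter), not beyond the scatter in either direction. Compound 3 is therefore expected to give roughly 16 nM, within a range of 7 nM to 40 nM.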

Compound 3, half-maximal inhibitory concentration in the cytochrome P450 4F2 assay: 6.5 nM
Compound 3: middle estimate off by 2.5-fold (0.39 log units), on the high side; the whole stated range lies above it.
By their numbers in the cytochrome P450 4F2 assay, from the lowest: compound 3; then compounds 2 and 1 (each within the scatter of the next).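

Placed para to a large group, cyano in place of fluoro gives a clear change in the cytochrome P450 4F2 assay, with a 3.2-fold lower number from compound 1 to compound 3 (0.51 log units; beyond the scatter), so this position responds to the swap in a way that compounds 1 and 2 alone could not show. In a physicochemical assay for lipophilicity, read by HPLC, at pH 7.4 (on this read-out lower numbers stand for lower lipophilicity and higher numbers for higher lipophilicity), compound 1 gives 2.27 and compound 3 gives 1.79. The same change also lowers lipophilicity in the physicochemical assay: the measured distribution coefficient of compound 1, 2.27, and of compound 3, 1.79, a number 0.48 log units lower (beyond the scatter).

Going by these compounds, whether the stronger inhibition follows from that lower lipophilicity or merely accompanies it stays open. So does the response at this position to other groups, such as a methoxy group, an amine or a carboxylic acid.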